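The source may hold more compounds than are shown below. What is called first, only, known or untested is meant among the compounds shown, and "the series" means these compounds.

Measured compounds in a functional assay on MGC-803 cells (Homo sapiens) for inhibition, read by MTT assay, with a stated time of 48 h; on this read-out higher numbers stand for weaker inhibition and lower numbers for stronger inhibition:
Compound 2 `COc1ccc(CNc2cc(OC)c(OC)c(OC)c2)cc1` gives 11400 nM.
Compound 1 `C/C=C/C(=O)N(Cc1ccc(OC)c(C)c1)c1cc(OC)c(OC)c(OC)c1` gives 14500 nM.
Compound 3 `COc1cc(NCc2ccccc2)cc(OC)c1OC` reaches only the limit of this assay, > 80000 nM.

Compound 2 has the lowest of the two numbers, with compound 1 within the scatter of it; the third value is a limit, as noted in the limit of > 80000 nM in this assay, at which 1 of the 3 values shown sits. Within the data shown here, the only measured step, an at least 7.0-fold higher number from compound 2 to compound 3 (0.84 log units; beyond the scatter), concerns loss of a methoxy and does not bear on the change now followed.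

Compound 4 `C/C=C/C(=O)N(Cc1ccc(OC)cc1)c1cc(OC)c(OC)c(OC)c1` differs from compound 2 by (prop-1-en-1-yl)carbonyl in place of hydrogen on a nitrogen on an aromatic ring. Compound 1 already carries that (prop-1-en-1-yl)carbonyl on the nitrogen and sits close to compound 2, so no shift beyond the scatter is expected: a 1.1-fold higher number from compound 2 to compound 4 (0.06 log units; within the scatter). Compound 4 is estimated at 13000 nM, within 5000 nM to 40000 nM.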

Compound 4, half-maximal inhibitory concentration: 450 nM
For compound 4 the middle estimate is 29-fold (1.46 log units) above the measured one; the whole stated range lies above it.
By their numbers in this assay, from the lowest: compound 4; then compounds 2 and 1 (each within the scatter of the next). At a limit, above all of these: compound 3.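

In this assay the nitrogen on the aromatic ring proves a sensitive place: (prop-1-en-1-yl)carbonyl in place of hydrogen there gives a 25-fold lower number from compound 2 to compound 4 (1.40 log units; beyond the scatter). Among the compounds shown, that gain appears only without the extra methyl on the aromatic carbon, since hydrogen in place of that methyl gives a 32-fold lower number from compound 1 to compound 4 (1.51 log units; beyond the scatter). Nothing shown accounts for either step. Still open, as far as these compounds go, is whether the carbon-carbon double bond of the (prop-1-en-1-yl)carbonyl matters, as a propanoyl or acetyl on the nitrogen would show. Also open, from the compounds shown here alone, is how a fluorine or an ethyl would behave on the aromatic carbon that carries the methyl in compound 1.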